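A few compounds are considered here, and "the series" means these few. Any claim that something is new, unique, unknown or untested is made for them only; others in the source may bear on it.

For the measured compounds named here, in a functional assay on a cell-free system (Platelet, plasma, Homo sapiens) for inhibition, read by turbidimetry, with a stated time of 3 min (a higher number here means a weaker inhibitor, a lower number a stronger inhibitor), compound 2 `O=C(c1cc(-c2ccc(Cl)cc2)n(-c2ccc(=O)[nH]n2)n1)N1CCOCC1` gives 12600 nM, the higher of the two numbers so far, against compound 1 `O=C(c1cc(-c2ccc(Cl)cc2)n(-c2ccc(=O)[nH]n2)n1)N1CCCCC1` at 2090 nM. Compound 3 `COc1ccc(-n2nc(C(=O)N3CCOCC3)cc2-c2ccc(Cl)cc2)cc1` differs from compound 2 by a group of 8 heavy atoms (7 carbon, 1 oxygen; one six-membered aromatic ring of carbon only) in place of a group of 7 heavy atoms (4 carbon, 2 nitrogen, 1 oxygen; one six-membered aromatic ring with 2 hetero atoms), on an aromatic nitrogen. Going by the values given here, the only measured step, a 6.0-fold higher number from compound 1 to compound 2 (0.78 log units; beyond the scatter), is modest and lies at the carbonyl carbon, not on the aromatic nitrogen, so it offers a guide to size only. Among the compounds with values here, no measured step shows a direction here, so no shift beyond the scatter is the central expectation in this assay, though a shift of that size either way remains possible. The estimated change is a 1.3-fold lower number from compound 2 to compound 3 (0.10 log units; within the scatter). For compound 3 the expected value is 10000 nM, with an estimated range of 2500 nM to 40000 nM.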

Compound 3, half-maximal inhibitory concentration: 7.3 nM
Beside the measured number, compound 3's estimate is 1400-fold (3.14 log units) above it; measured number outside the range, below it.
By their numbers in this assay, from the lowest: compound 3; then compound 1; then compound 2.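

The aromatic nitrogen is a far more sensitive position in this assay than the carbonyl carbon: 4-methoxyphenyl in place of the six-membered ring with 2 hetero atoms gives a 1700-fold lower number from compound 2 to compound 3 (3.24 log units; beyond the scatter) and outweighs a 6.0-fold higher number from compound 1 to compound 2 (0.78 log units; beyond the scatter). The swap changes several features at once, including ring hetero atoms, hydrogen-bond donors and the methoxy group, and no available data separate their contributions or explain the gain.

Still open, as far as these compounds go, is whether plain phenyl or a pyridine ring on this nitrogen would hold the gain. From the compounds shown here alone, it is also open whether piperidin-1-yl would still outperform morpholin-4-yl alongside 4-methoxyphenyl.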